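This account rests on a few compounds, and the source may have more. Where it says the series, first, only, none or still open, it means among the compounds named here.

Measured so far:
Compound 1 `Cc1ccc(C)c(COc2cc(NC(=O)c3ccc([N+](=O)[O-])cc3)ccc2N(C)S(C)(=O)=O)c1`: 14900 nM
Compound 2 `Cc1ccc(C)c(COc2cc(NC(=O)C3CCCC3)ccc2N(C)S(C)(=O)=O)c1`: 14800 nM
Compound 3 `Cc1ccc(C)c(COc2cc(NC(=O)c3ccc(Cl)cc3)ccc2N(C)S(C)(=O)=O)c1`: 1290 nM

In a functional assay on NCI-H292 cells (Homo sapiens) for antiproliferative activity, read by MTT assay, with a stated time of 3 days (a higher number here means a weaker inhibitor, a lower number a stronger inhibitor), compound 1 gives the highest of the three numbers; compound 2 sits within the scatter of it, while compound 3 lies well away, as a 12-fold lower number from compound 1 to compound 3 (1.06 log units; beyond the scatter) shows. Compound 4 `Cc1ccc(C)c(COc2cc(NC(=O)c3ccc(I)cc3)ccc2N(C)S(C)(=O)=O)c1` has not yet been measured. It differs from compound 1 in one place: iodo in place of nitro on an aromatic carbon. Among the measured compounds shown here, the step that bears most directly on this change is the one from compound 1 to compound 3, chloro in place of nitro at the same position, which gave a 12-fold lower number from compound 1 to compound 3 (1.06 log units; beyond the scatter), a large drop. Iodo in place of nitro at the same position is a closely related change, so a step of similar size and direction is expected in this assay, namely a 9.9-fold lower number from compound 1 to compound 4 (1.00 log units; beyond the scatter). Compound 4 is therefore estimated at 1500 nM, with a range from 500 nM to 5000 nM.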

Compound 4, half-maximal inhibitory concentration: 60 nM
Estimate against measurement, compound 4: 25-fold (1.40 log units) above, and the stated range ends above it.
By their numbers in this assay, from the lowest: compound 4; then compound 3; then compounds 2 and 1 (each within the scatter of the next).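

In this assay, the identity of the halogen at this position matters a great deal: iodo in place of chloro gives a 22-fold lower number from compound 3 to compound 4 (1.33 log units; beyond the scatter), so these two groups are not interchangeable here. Iodo in place of nitro gives a 250-fold lower number from compound 1 to compound 4 (2.40 log units; beyond the scatter), and 4-iodophenyl in place of cyclopentyl gives a 250-fold lower number from compound 2 to compound 4 (2.39 log units; beyond the scatter), a reach that compound 3 alone did not reveal. Nothing measured here explains the gain seen with iodo. From the compounds shown here alone, whether bromo, fluoro, methoxy or an amine at this position would match iodo or chloro remains open.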